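The compounds below may be only part of what the source reports. "The series", "measured", "known", "first", "only" and "open" are said of these compounds alone.

Of the compounds shown here, three have so far been measured in an assay on isolated protein for displacement of a labelled ligand from growth hormone secretagogue receptor type 1 (Homo sapiens), with a stated time of 1 h; a higher number here means a weaker inhibitor, a lower number a stronger inhibitor. Compound 1 `CC(C)(N)C(=O)N[C@H](COCc1ccccc1)c1nnnn1CC#N` gives 4170 nM. Compound 2 `CC(C)(N)C(=O)N[C@H](COCc1ccccc1)c1nnn(Cc2ccc(NS(C)(=O)=O)cc2)n1` reaches only the limit of the assay, reported as > 5000 nM, so no number is known for it. Compound 3 `COC(=O)C(c1ccccc1)n1nnc([C@@H](COCc2ccccc2)NC(=O)C(C)(C)N)n1` likewise stops at the limit, reported as > 5000 nM. Among the measured compounds shown here, compound 3 therefore stands at the limit of > 5000 nM in this assay, at which 2 of the 3 values shown sit, and because two of the three results are limits, no measured step between neighbouring structures is available to guide the next change.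

The next compound, compound 4 `CC(C)(N)C(=O)N[C@H](COCc1ccccc1)c1nnn(CC#N)n1`, differs from compound 3 by cyanomethyl in place of methoxycarbonyl)(benzyl on an aromatic nitrogen. Compound 4 thus carries the same cyanomethyl group as compound 1, which gives 4170 nM in this assay. The step of an at least 1.2-fold lower number from compound 3 to compound 4 (0.09 log units; that floor lies within the scatter) is expected to move the result out of the limit into a measurable number, of modest size. Compound 4 is therefore estimated at 4000 nM, within a range from 1500 nM to 15000 nM.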

Compound 4, inhibition constant: > 5000 nM
Compound 4: only a limit was reported (the forecaster's own chance of this, stated with the estimate: 40%); at least 1.2-fold (0.09 log units) between middle value and limit.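

Compound 4 reaches only a limit, > 5000 nM, so cyanomethyl in place of methoxycarbonyl)(benzyl on this aromatic nitrogen gives no measurable number, and the steps joining compound 4 to compound 2 and compound 3 cannot be read. Among the compounds shown here, the one readable comparison, 2-(cyanomethyl)-2H-tetrazol-5-yl in place of 1-(cyanomethyl)-1H-tetrazol-5-yl, gives an at least 1.1-fold higher number from compound 1 to compound 4 (0.07 log units; that floor lies within the scatter), so the data show no clear difference between these two placements of the cyanomethyl group, though the real gap could be larger. Large and small groups on this nitrogen now end alike: the limit of > 5000 nM in this assay, at which 3 of the 4 values shown sit.

Going by these compounds, how far compound 2, compound 3 and compound 4 lie past that limit remains unknown. On these data alone, it is also open whether a plain methyl, or a short chain ending in an amine or a carboxylic acid, on this nitrogen would give a measurable number.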